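Bromo entry on the fused ring of compound 3

This account rests on a few compounds, and the source may have more. Where it says the series, first, only, none or still open, it means among the compounds named here.

Compound 3 `COc1ccc(C2CC(c3ccc4ccccc4c3)=NN2C2=NC(=O)/C(=C3\C(=O)Nc4ccccc43)S2)cc1` gives 2470 nM in a functional assay on cells (Cancer cell lines, Homo sapiens) for cytotoxicity, read by sulforhodamine B assay, with a stated time of 48 h (on this read-out lower numbers stand for stronger inhibition of growth and higher numbers for weaker inhibition of growth), the highest of the three numbers recorded: compound 2 `COc1ccc(C2=NN(C3=NC(=O)/C(=C4\C(=O)Nc5ccc(Br)cc54)S3)C(c3ccc(OC)cc3)C2)cc1` gives 710 nM and compound 1 `COc1ccc(C2CC(c3ccccc3)=NN2C2=NC(=O)/C(=C3\C(=O)Nc4ccc(Br)cc43)S2)cc1` gives 660 nM, both lower by margins beyond the scatter. Compound 4 `COc1ccc(C2CC(c3ccc4ccccc4c3)=NN2C2=NC(=O)/C(=C3\C(=O)Nc4ccc(Br)cc43)S2)cc1` differs from compound 3 by bromo in place of hydrogen on an aromatic carbon. For the measured compounds named here, the only single-point step measured, a 1.1-fold higher number from compound 1 to compound 2 (0.03 log units; within the scatter), concerns a methoxy on another ring and does not bear on this change. Going by the values given here, compounds 1 and 2 carry the bromo but differ from compound 3 at a second place too, so their values show only that the bromo-bearing pair sits lower. For compound 4 a moderate lowering of the number, a 1.8-fold lower number from compound 3 to compound 4 (0.25 log units; within the scatter), is expected. Compound 4 is estimated at 1400 nM, with a range from 500 nM to 4000 nM.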

Compound 4, concentration for total growth inhibition: 510 nM
Compound 4: the middle estimate sits 2.7-fold (0.44 log units) above what was measured, within the range that was stated.
By their numbers in this assay, from the lowest: compounds 4, 1 and 2 (each within the scatter of the next); then compound 3.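

In this assay, for the compounds shown here, bromo in place of hydrogen on this aromatic carbon gives a 4.8-fold lower number from compound 3 to compound 4 (0.69 log units; beyond the scatter) with naphthalen-2-yl present on both sides, the first direct reading of this change. With bromo present, the group on the carbon with a double bond to nitrogen separates nothing, as a 1.4-fold lower number from compound 2 to compound 4 (0.14 log units; within the scatter) and a 1.3-fold lower number from compound 1 to compound 4 (0.11 log units; within the scatter) show. Nothing on hand explains the bromo step.

From the compounds shown here alone, whether chloro, an amine or a carboxylic acid at this carbon would match bromo stays open. Also open, going by these compounds, is whether the bromo step holds with phenyl or 4-methoxyphenyl in place of naphthalen-2-yl.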